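The compounds below may be only part of what the source reports. "The series", "measured", "known", "first", "only" and "open" are said of these compounds alone.

Among the compounds with values here, the two compounds measured so far share one core and differ only in the group on the amine nitrogen. Compound 1, `O=C1C(Nc2ccccc2F)=CC(=O)c2c1nc1n2[C@H]2OC[C@@H](O)[C@H]2OC1`, is tested in a functional assay on MCF7 cells (Homo sapiens) for inhibition, read by sulforhodamine B assay (a lower number here means a stronger inhibitor, a higher number a weaker inhibitor), and there compound 1 gives only a limit, > 4000 nM. Compound 2, `O=C1C=C(NC2CCCC2)C(=O)c2c1nc1n2[C@H]2OC[C@@H](O)[C@H]2OC1`, in this assay also gives only a limit, > 16000 nM. Where compound 2 stands is thus known only as a limit, the other value shown being a limit as well, so no step between measured compounds can be counted and nothing beyond the scatter has been seen. Compound 3, `COc1cccc(NC2=CC(=O)c3nc4n(c3C2=O)[C@H]2OC[C@@H](O)[C@H]2OC4)c1`, differs from compound 2 in one place: 3-methoxyphenyl in place of cyclopentyl on an amine nitrogen. Compound 3 is expected to remain weak in this assay, given that compound 1 sits at the limit of > 4000 nM in this assay, at which 1 of the 2 values shown sits, and compound 2 at the limit of > 16000 nM in this assay, at which 1 of the 2 values shown sits, and the expected step of an at least 1.3-fold lower number from compound 2 to compound 3 (0.12 log units; that floor lies within the scatter) is not expected to exceed the scatter. Compound 3 is estimated at 12000 nM, within 3000 nM to 40000 nM.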

Compound 3, half-maximal inhibitory concentration: > 4000 nM
Compound 3: a limit, no number (the forecaster's own chance of this, stated with the estimate: 65%); the middle value lies beyond the limit too.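

Compound 3 gives only a limit in this assay, > 4000 nM. Compound 2 also gives only a limit, > 16000 nM, so no step can be read between compound 2 and compound 3. The compounds shown leave open whether any group on the amine nitrogen gives a real number rather than a limit.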